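A Carboxylic Acid Chain Enters Where Compound 2 Sits at the Limit

The source may hold more compounds than are shown below. What is called first, only, known or untested is meant among the compounds shown, and "the series" means these compounds.

Of the compounds shown here, three of a shared core have been measured in a functional assay on FaDu cells (Homo sapiens) for cytotoxicity, read by MTT assay, with a stated time of 72 h; a lower number here means that less compound is tolerated, a higher number that more compound is tolerated. Compound 1 `COc1ccc(NC(=O)C(=O)c2cn(C(C)C)c3cc(Cl)ccc23)cn1` gives 1770 nM, and compound 3 `COCCn1cc(C(=O)C(=O)Nc2ccc(OC(C)(C)C)nc2)c2ccccc21` gives 858 nM. Compound 2 `COc1ccc(NC(=O)C(=O)c2cn(CC(C)(C)OC)c3ccccc23)cn1` stands apart: its result of > 10000 nM is a limit of the assay and not a number, so only a bound is known for it. Among the three values it is the one at the limit of > 10000 nM in this assay, at which 1 of the 3 values shown sits, which places it at the least-toxic end of what the assay can report.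

Compound 4 `COc1ccc(NC(=O)C(=O)c2cn(C(C)(C)COCC(=O)O)c3ccccc23)cn1` has not yet been measured. It differs from compound 2 in one place (a group of 9 heavy atoms (6 carbon, 3 oxygen; no ring) in place of a group of 6 heavy atoms (5 carbon, 1 oxygen; no ring), on an aromatic nitrogen), where the 2-methoxy-2-methylpropyl leaves and a longer chain carrying a carboxylic acid enters, on an aromatic nitrogen of the five-membered ring of the fused system.

Going by the values given here, no measured pair shows how such a change moves the cytotoxicity, so no direction can be read from the data. Since compound 2 already sits at a limit, the step from compound 2 to compound 4 in this assay is expected to be none beyond the scatter. Compound 4 is therefore estimated at 15000 nM, with a likely range from 5000 nM to 50000 nM. The expected step is a step that the limit leaves unreadable from compound 2 to compound 4, and the assay may again return only a limit.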

Compound 4, concentration lethal to 50% of the cells: > 10000 nM
Compound 4: only a limit was reported (the forecaster's own chance of this, stated with the estimate: 70%); the middle value lies beyond the limit too.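

Compound 2 and compound 4 each return only a limit of the assay and not a number, so no step between them can be read in this assay: the limit of > 10000 nM in this assay, at which 2 of the 4 values shown sit.

The compounds shown leave open how far either compound lies past that limit, and whether exchanging the 2-methoxy-2-methylpropyl for the longer chain carrying a carboxylic acid changes the cytotoxicity at all.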